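A few compounds are considered here, and "the series" means these few. Any claim that something is new, unique, unknown or untested is made for them only; others in the source may bear on it.

Measured so far in a functional assay on A549 cells (Homo sapiens) for cytotoxicity, read by MTT assay, with a stated time of 72 h; on this read-out lower numbers stand for stronger inhibition and higher numbers for weaker inhibition:
- compound 1 `Cc1ccc(S(=O)(=O)c2nc3ccccc3nc2Nc2ccccc2)cc1`: 12500 nM
- compound 2 `Cc1ccc(S(=O)(=O)c2nc3ccccc3nc2Nc2ccc(F)cc2)cc1`: 39200 nM

Compound 2 stands at the higher of the two numbers in this assay; its nearest neighbour is compound 1, and the step of a 3.1-fold higher number from compound 1 to compound 2 (0.50 log units; beyond the scatter) is the only one measured in the series, a fluoro in place of hydrogen on an aromatic carbon.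

Compound 3 `Cc1ccc(S(=O)(=O)c2nc3ccccc3nc2Nc2ccc(C(F)(F)F)cc2)cc1` is not yet measured. It differs from compound 2 by trifluoromethyl in place of fluoro on an aromatic carbon, that is, 4-fluorophenyl to 4-(trifluoromethyl)phenyl, the group sitting para to a large group. Among the compounds with values here, no measured step carries a trifluoromethyl, so the step of a 3.1-fold higher number from compound 1 to compound 2 (0.50 log units; beyond the scatter) is the only guide, and it points toward a higher number on adding a substituent at that carbon.

On that basis compound 3 is expected to give a number within scatter of compound 2 or somewhat higher, an estimated step of a 1.3-fold higher number from compound 2 to compound 3 (0.11 log units; within the scatter). The estimate for compound 3 in this assay is 50000 nM, with a range from 18000 nM to 140000 nM.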

Compound 3, half-maximal inhibitory concentration: 13500 nM
Compound 3: middle estimate off by 3.7-fold (0.57 log units), on the high side; the whole stated range lies above it.
By their numbers in this assay, from the lowest: compounds 1 and 3 (each within the scatter of the next); then compound 2.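

At the carbon para to a large group, adding a substituent does not by itself raise the number in this assay: there is a 2.9-fold lower number from compound 2 to compound 3 (0.46 log units; beyond the scatter) and a 1.1-fold higher number from compound 1 to compound 3 (0.03 log units; within the scatter) for the swap to trifluoromethyl, which puts that group within the scatter of hydrogen. The rise seen with fluoro therefore does not extend to trifluoromethyl, and among these three compounds only compound 2 stands apart, beyond the scatter of both others. Nothing available accounts for the different behaviour of fluoro and trifluoromethyl at this carbon.

Three compounds cannot show whether fluoro is the exception or whether the hydrogen and trifluoromethyl compounds mark the usual level at this carbon. From the compounds shown here alone, a methoxy group, an amine or a carboxylic acid at the same carbon would be needed to separate these readings, and whether the pattern holds elsewhere on the ring remains open.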